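This account rests on a few compounds, and the source may have more. Where it says the series, first, only, none or still open, it means among the compounds named here.

Working notes on the series. For the measured compounds named here, of the two compounds measured so far, compound 2 `O=C(Nc1ccc(-n2ncc3c(Br)cccc32)cc1)Nc1ccc(Cl)c(C(F)(F)F)c1` holds the lowest number in a functional assay on LoVo cells (Homo sapiens) for cytotoxicity, read by MTT assay, with a stated time of 72 h (a higher number here means a weaker inhibitor, a lower number a stronger inhibitor), giving 1700 nM; its nearest neighbour is compound 1 `O=C(Nc1ccc(-n2ncc3c(Cl)cccc32)cc1)Nc1ccc(Cl)c(C(F)(F)F)c1`, which in this assay gives 3600 nM. Going by the values given here, the one measured step, a 2.1-fold lower number from compound 1 to compound 2 (0.33 log units; beyond the scatter), was a modest move. Compound 3 `O=C(Nc1ccc(-n2ncc3ccccc32)cc1)Nc1ccc(Cl)c(C(F)(F)F)c1` is not yet measured; it differs from compound 2 in that (hydrogen in place of bromo on an aromatic carbon). Among the compounds with values here, only that one step bears on this position, and it shows that the halogen there is not indifferent, so a modest rise in the number, that is a weaker inhibitor, is expected as the step of a 2.4-fold higher number from compound 2 to compound 3 (0.37 log units; beyond the scatter). For compound 3 the estimate in this assay is 4000 nM, within 1500 nM to 11000 nM.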

Compound 3, half-maximal inhibitory concentration: 8700 nM
Beside the measured number, compound 3's estimate is 2.2-fold (0.34 log units) below it; low and high end bracket the measured number.
By their numbers in this assay, from the lowest: compound 2; then compound 1; then compound 3.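

In this assay, taking the halogen away altogether costs more than exchanging one halogen for the other: the hydrogen compound is the weakest of the three (a 5.1-fold higher number from compound 2 to compound 3 (0.71 log units; beyond the scatter); a 2.4-fold higher number from compound 1 to compound 3 (0.38 log units; beyond the scatter)). At this place on the shared core, then, both bromo and chloro give a stronger inhibitor than hydrogen, with bromo ahead of chloro. No measurement at hand explains this order.

The compounds shown leave open whether iodo would extend the halogen order. They also leave open how a methyl, methoxy or amine at this place would compare with bromo.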